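From a carboxy chain to a dimethylamino chain

The source may report more compounds than this note shows. Statements on the series, on what has been measured and on what is new or still open speak of the compounds shown alone.

Compound 1 `CCCn1c(=O)n(CCC(C)=O)c(=O)c2[nH]cnc21` gives 3500 nM
Compound 2 `CCCn1c(=O)n(C)c(=O)c2c1ncn2CCC(=O)O` gives > 100000 nM

Both results come from a functional assay (trachea) with Cavia porcellus as the target; a higher number here means that more compound is needed for the effect, a lower number that less compound is needed. Compound 2 stands at the limit of > 100000 nM in this assay, at which 1 of the 2 values shown sits, so its result is a limit and not a number.

Compound 3 `CCCn1c(=O)n(C)c(=O)c2c1ncn2CCN(C)C` keeps the core of compound 2 and changes only the end of its chain: dimethylamino in place of carboxy on a saturated chain carbon, two bonds along the chain from an aromatic nitrogen. In words, this puts dimethylamino in place of carboxy on a saturated chain carbon, two bonds along the chain from an aromatic nitrogen. For the measured compounds named here, no measured pair of compounds shows this change.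

Going by the values given here, the only guide is compound 1 at 3500 nM, a related compound with a true number. A move towards less compound needed is therefore expected, and the estimated step is an at least 3.3-fold lower number from compound 2 to compound 3 (0.52 log units; beyond the scatter). Compound 3 is estimated at 30000 nM, with an expected range of 8000 nM to 100000 nM.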

Compound 3, half-maximal effective concentration: > 100000 nM
Compound 3 gave a limit, no number; the forecaster's own chance of this, stated with the estimate: 30%; at least 3.3-fold (0.52 log units) between middle value and limit.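

No step can be read from compound 2 to compound 3, because the results of both compounds in this assay are limits and not numbers: the limit of > 100000 nM in this assay, at which 2 of the 3 values shown sit.

The compounds shown leave open whether carboxy or dimethylamino at this chain end gives the lower number, and by how much.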